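Methoxy in Place of Chloro on a Weak Inhibitor

A few compounds are considered here, and "the series" means these few. Any claim that something is new, unique, unknown or untested is made for them only; others in the source may bear on it.

Among the compounds with values here, compound 1 `C#CCNC1CCc2c(SCCc3cccc(Cl)c3)cccc21` is the only compound here with a numerical result: in an assay on isolated protein for inhibition of Amine oxidase [flavin-containing] B (Homo sapiens) (on this read-out higher numbers stand for weaker inhibition and lower numbers for stronger inhibition), compound 1 gives 82400 nM. Compound 2 `C#CCNC1CCc2c(SCc3cccc(Br)c3)cccc21` reaches only the limit of > 100000 nM in this assay, so no number is known for it. Compound 3 `C#CCNC1CCc2c(SCCc3cccc(OC)c3)cccc21` differs from compound 1 in one place: methoxy in place of chloro on an aromatic carbon. No measured step of this kind exists among these compounds, so the expected step of a 1.1-fold higher number from compound 1 to compound 3 (0.04 log units; within the scatter) stays within the usual scatter, with no clear direction. Compound 3 is thus estimated at 90000 nM, likely between 30000 nM and 300000 nM.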

Compound 3, half-maximal inhibitory concentration: 28700 nM
Compound 3: middle estimate off by 3.1-fold (0.50 log units), on the high side; the whole stated range lies above it.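

The aromatic position is not indifferent to what sits on it: methoxy in place of chloro gives a 2.9-fold lower number from compound 1 to compound 3 (0.46 log units; beyond the scatter) in this assay and so a real, if modest, gain in inhibition. Within the data shown here, this is the first measured change at this position on the shared core, and it is a single step on a weak inhibitor. Nothing measured here explains why the swap has this effect.

Going by these compounds, it remains open whether a hydroxyl, an amine or an ethoxy group in the same place would go further. On these data alone, whether methoxy gives a similar step on a longer chain also remains open.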